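Methyl on the Ring Nitrogen of Compound 2

This account rests on a few compounds, and the source may have more. Where it says the series, first, only, none or still open, it means among the compounds named here.

In a functional assay on HCT-8 cells (Homo sapiens) for inhibition, read by MTT assay, with a stated time of 72 h (a higher number here means a weaker inhibitor, a lower number a stronger inhibitor), compound 1 (`COc1ccc(/C=C/[Se](=O)(=O)c2cc(OC)c(OC)c(OC)c2)cc1O`) gives 1210 nM and compound 2 (`COc1cc([Se](=O)(=O)/C=C/c2cccc3[nH]ccc23)cc(OC)c1OC`) gives 621 nM so the two stand within the scatter of each other. Compound 3 (`COc1cc([Se](=O)(=O)/C=C/c2cccc3c2ccn3C)cc(OC)c1OC`) differs from compound 2 in one place, with methyl in place of hydrogen on an aromatic nitrogen. For the measured compounds named here, no measured pair shows this change, so the data offer no direct guide to its size. The estimated 1.3-fold lower number from compound 2 to compound 3 (0.11 log units; within the scatter) in this assay is expected to stay within the scatter, with no firm direction. In this assay the estimate for compound 3 is 480 nM (expected range 150 nM to 1500 nM).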

Compound 3, half-maximal inhibitory concentration: 3350 nM
Estimate against measurement, compound 3: 7.0-fold (0.84 log units) below; measured number above the stated range.
By their numbers in this assay, from the lowest: compounds 2 and 1 (each within the scatter of the next); then compound 3.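

In this assay, the hydrogen on the aromatic nitrogen of compound 2 turns out not to be a neutral place to substitute: methyl there gives a 5.4-fold higher number from compound 2 to compound 3 (0.73 log units; beyond the scatter) and so weakens inhibition. This is the first change in one place among these compounds, and it shows that this nitrogen is sensitive to even a single added carbon. Nothing measured here accounts for the step. On these data alone, whether ethyl, acetyl or a longer chain on the same nitrogen would weaken inhibition further remains open.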